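A few compounds are considered here, and "the series" means these few. Any claim that something is new, unique, unknown or untested is made for them only; others in the source may bear on it.

Measured compounds:

Compound 1, `Cc1ccc(NC(=O)c2ccc(OCCCCn3ccnc3)c(Br)c2)cc1Nc1nccc(-c2cccnc2)n1`, gives 12000 nM in a functional assay on K562 cells (Homo sapiens) for cytotoxicity, read by XTT assay, with a stated time of 24 h; on this read-out lower numbers stand for stronger inhibition and higher numbers for weaker inhibition.
Compound 2, `COc1ccc(C(=O)Nc2ccc(C)c(Nc3nccc(-c4cccnc4)n3)c2)cc1OCCCCn1ccnc1`, gives 10100 nM in this assay.
Compound 3, `COc1ccc(C(=O)Nc2ccc(C)c(Nc3nccc(-c4cccnc4)n3)c2)c(OCCCCn2ccnc2)c1`, gives 58900 nM in this assay.

Among these three, compound 3 stands with the highest number, which on this read-out means the weakest inhibition of the cancer cells. The gaps from compound 3 down to compound 1 and to compound 2 both lie beyond the usual scatter of the measurement, so compound 3 is genuinely the least potent of the three.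

Compound 4, `Cc1ccc(NC(=O)c2ccc(I)cc2OCCCCn2ccnc2)cc1Nc1nccc(-c2cccnc2)n1`, is not yet measured. Starting from compound 3, the change is iodo in place of methoxy on an aromatic carbon. Among the compounds with values here, nothing among the measured pairs matches this exact swap, so no step of known size can be borrowed. Because compound 3 sits at 58900 nM, the expectation for compound 4 is a move toward stronger inhibition of modest size, a 2.4-fold lower number from compound 3 to compound 4 (0.37 log units; beyond the scatter), though the direction is uncertain and a change within the scatter would not surprise. The estimate for compound 4 is 25000 nM, within a range from 8000 nM to 80000 nM.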

Compound 4, half-maximal inhibitory concentration: 57400 nM
The estimate for compound 4 lay 2.3-fold (0.36 log units) below the measured number; measured number inside the range.
By their numbers in this assay, from the lowest: compounds 2 and 1 (each within the scatter of the next); then compounds 4 and 3 (each within the scatter of the next).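

Replacing methoxy with iodo, at the aromatic carbon para to a large group and meta to a 4-(1H-imidazol-1-yl)butoxy group, gives a 1.0-fold lower number from compound 3 to compound 4 (0.01 log units; within the scatter) in this assay. Within the data shown here, this is the first pair here that differs in one place, and it shows that, on this scaffold, this read-out does not separate the two groups at this position, even though the swap removes the hydrogen-bond acceptor of the methoxy. No measurement of any other property accompanies these compounds, so the data offer no explanation for this result.

The compounds shown leave open whether a different group at this position, such as an amine, a carboxylic acid or a longer alkoxy chain, would shift the number beyond the scatter. They also leave open whether this swap would give the same result on another core.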